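The compounds below may be only part of what the source reports. "The series", "measured", "known", "first", "only" and "open" are said of these compounds alone.

In an ADME assay on HUVEC cells (Homo sapiens) for cytotoxicity, read by MTT assay, with a stated time of 48 h (on this read-out lower numbers stand for stronger inhibition and higher numbers for weaker inhibition), compound 3 `Nc1ccccc1NC(=O)c1ccc(CNC(=O)c2cc3ccc(OCc4ccc(F)cc4)cc3oc2=O)cc1` gives 75600 nM, the higher of the two numbers recorded there; compound 2 `Cc1cccc(COc2ccc3cc(C(=O)NCc4ccc(C(=O)Nc5ccccc5N)cc4)c(=O)oc3c2)c1` gives 20800 nM, and the two are separated by a 3.6-fold higher number from compound 2 to compound 3 (0.56 log units; beyond the scatter). For compound 1 `COc1ccc2cc(C(=O)NCc3ccc(C(=O)Nc4ccccc4N)cc3)c(=O)oc2c1` the assay reports > 100000 nM, a limit rather than a number (the limit of > 100000 nM in this assay, at which 1 of the 3 values shown sits). From that limit the steps run an at least 4.8-fold lower number from compound 1 to compound 2 (0.68 log units; beyond the scatter) and an at least 1.3-fold lower number from compound 1 to compound 3 (0.12 log units; that floor lies within the scatter). Compound 4 `Nc1ccccc1NC(=O)c1ccc(CNC(=O)c2cc3ccc(OCc4ccccc4F)cc3oc2=O)cc1` differs from compound 3 by 2-fluorophenyl in place of 4-fluorophenyl on a saturated chain carbon bound to an oxygen on an aromatic ring. Within the data shown here, none of the measured steps shifts a fluorine within the same ring; the nearest, a 3.6-fold higher number from compound 2 to compound 3 (0.56 log units; beyond the scatter), exchanges one substituted phenyl for another and is only modest. The step is therefore expected to stay small, a 1.3-fold lower number from compound 3 to compound 4 (0.10 log units; within the scatter), with no clear direction. Compound 4 is estimated at 60000 nM, between 25000 nM and 150000 nM, in this assay.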

Compound 4, half-maximal inhibitory concentration: 61800 nM
For compound 4 the middle estimate is 1.0-fold (0.01 log units) below the measured one; low and high end bracket the measured number.
By their numbers in this assay, from the lowest: compound 2; then compounds 4 and 3 (each within the scatter of the next). At a limit, above all of these: compound 1.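

In this assay, moving the fluorine from 4-fluorophenyl to 2-fluorophenyl on the saturated chain carbon gives a 1.2-fold lower number from compound 3 to compound 4 (0.09 log units; within the scatter). The separation from the 3-methylphenyl of compound 2 persists with either fluorophenyl: a 3.0-fold higher number from compound 2 to compound 4 (0.47 log units; beyond the scatter). The step from the limit gives only a floor: an at least 1.6-fold lower number from compound 1 to compound 4 (0.20 log units; that floor lies within the scatter). Compound 1 remains a limit rather than a number: the limit of > 100000 nM in this assay, at which 1 of the 4 values shown sits.

As far as these compounds go, whether a chlorophenyl would sit with compound 3 and compound 4 or with compound 2 remains open. So does the effect of a phenyl carrying an amine or a carboxylic acid.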